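The source may report more compounds than this note shows. Statements on the series, on what has been measured and on what is new or still open speak of the compounds shown alone.

Measured so far:
compound 1, `CC(C)CCn1nc(-c2cccs2)c(O)c(C2=NS(=O)(=O)c3cc(S(=O)(=O)N(C)C)ccc3N2)c1=O`: 0.183 h
compound 2, `CC(C)CCn1nc(C2CCC2)c(O)c(C2=NS(=O)(=O)c3cc(NS(C)(=O)=O)ccc3N2)c1=O`: 0.317 h

Both numbers come from an in vitro ADME assay on microsomes from liver (Homo sapiens) for metabolic stability, tested at 5 uM; on this read-out lower numbers stand for a shorter-lived compound and higher numbers for a longer-lived compound. In this assay compound 1 gives 0.183 h and compound 2 gives 0.317 h; the two values lie within the usual scatter of each other, so on this read-out neither compound can be set apart from the other, and compound 2 cannot be called longer-lived on these two numbers alone. Within the data shown here, no pair of measured compounds that differ in one place has been run, so the series so far carries no measured step to lean on.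

Compound 3, `CC(C)CCn1nc(CCC(F)(F)F)c(O)c(C2=NS(=O)(=O)c3cc(NS(C)(=O)=O)ccc3N2)c1=O`, is the next one to be measured. It differs from compound 2 in one place: 3,3,3-trifluoropropyl in place of cyclobutyl on an aromatic carbon. Among the measured compounds shown here, no measured pair shows what such an exchange does in this assay, so the expectation rests on the two known values and on the size of the change alone. The step of a 1.0-fold higher number from compound 2 to compound 3 (0.00 log units; within the scatter) is expected to stay within the scatter, in no settled direction. The estimate for compound 3 in this assay is 0.32 h, with a range from 0.15 h to 0.65 h.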

Compound 3, half-life: 0.517 h
Compound 3: the middle estimate sits 1.6-fold (0.21 log units) below what was measured; the range from low to high includes it.
By their numbers in this assay, from the lowest: compounds 1, 2 and 3 (each within the scatter of the next, the first and the last beyond it).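

The series now has its first measured step in this assay: with 3,3,3-trifluoropropyl in place of cyclobutyl on the aromatic carbon ortho to the hydroxy group, the result is a 1.6-fold higher number from compound 2 to compound 3 (0.21 log units; within the scatter) and the exchange stays inside the usual scatter. At this position, then, an open chain carrying three fluorine atoms and a four-membered carbon ring cannot be told apart on this read-out, so the ring is not shown to be needed for the half-life seen with compound 2. No supporting data bear on why the two groups read alike.

As far as these compounds go, what stays open is whether the fluorine atoms or the chain shape matter at all here, since a plain propyl chain, a cyclopentyl ring or a longer chain at the same place would separate those two features. Among these compounds, it is also open whether this exchange would read the same with a different group elsewhere on the shared core, because the single step rests on one background and cannot be extended past compound 2 and compound 3.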